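The source may report more compounds than this note shows. Statements on the series, on what has been measured and on what is new or still open speak of the compounds shown alone.

Working notes on the series. Within the data shown here, in a functional assay on P388 cells (Mus musculus) for cytotoxicity (on this read-out lower numbers stand for an effect already at smaller amounts and higher numbers for an effect only at larger amounts of compound), compound 1 (`CCOc1cc(-c2ccccc2)nc2ccccc12`) gives 6 ug/mL, the higher of the two numbers so far. Compound 3 (`Oc1ccc2nc(-c3ccccc3)cc(O)c2c1`) gives 2.86 ug/mL, a gap beyond the usual scatter, but it differs from compound 1 in more than one place and does not bear on the change considered here. Compound 2 (`c1ccc(COc2cc(-c3ccccc3)nc3ccccc23)cc1`) reads > 10 ug/mL, which is a limit of the assay and not a number.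

Compound 4 (`CC(C)Oc1cc(-c2ccccc2)nc2ccccc12`) follows from compound 1 by methyl in place of hydrogen on a saturated chain carbon bound to an oxygen on an aromatic ring and a saturated chain carbon, ethoxy to isopropoxy.

Among the measured compounds shown here, the only measured step on this chain is an at least 1.6-fold higher number from compound 1 to compound 2 (0.22 log units; that floor lies within the scatter), with phenyl in place of methyl, and it ends at the limit of > 10 ug/mL in this assay, at which 1 of the 3 values shown sits. For the measured compounds named here, with that step as the sole guide, no shift beyond the scatter is expected in this assay. The estimated step is no change at the digits printed from compound 1 to compound 4 (within the scatter). For compound 4 the expected value is 6 ug/mL, with an estimated range of 2.5 ug/mL to 12 ug/mL.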

Compound 4, half-maximal effective concentration: > 10 ug/mL
Compound 4 gave a limit, no number (the forecaster's own chance of this, stated with the estimate: 20%); middle value at least 1.6-fold (0.22 log units) away from the limit.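

In this assay, the one added methyl of ethoxy to isopropoxy gives an at least 1.6-fold higher number from compound 1 to compound 4 (0.22 log units; that floor lies within the scatter), so this small change on the saturated chain carbon bound to the oxygen already ends where the larger benzyl group ended. Compound 2 and compound 4 each stand at a limit of the assay and not at a number: the limit of > 10 ug/mL in this assay, at which 2 of the 4 values shown sit. The step between these two cannot be read, so isopropyl and benzyl on this oxygen cannot be ranked.

On these data alone, how far compound 4 truly lies from compound 1 remains open, since the printed floor does not pass the scatter. Also open, as far as these compounds go, is whether a longer unbranched chain, or an amine or a carboxylic acid carried on the chain on this oxygen, would return a number in this assay.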